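Swapping the furan-2-yl ring for 2,6-dichlorophenyl

The source may hold more compounds than are shown below. What is called first, only, known or untested is meant among the compounds shown, and "the series" means these compounds.

Three compounds have been measured in a functional assay on the whole organism (strain albino) for inhibition, with Rattus norvegicus as the target, read by paw edema, with stated times of 30 min and 3 h, at a dose of 100 mg/kg by the oral route; a lower number here means less inhibition, a higher number more inhibition at the dose given (going by the name of the read-out):
compound 1 `COc1ccc(C2=NNC(c3c(Cl)cccc3Cl)C2)cc1OC` gives 58%
compound 2 `COc1ccc(C2=NN(C(=O)CO[N+](=O)[O-])C(c3c(Cl)cccc3Cl)C2)cc1OC` gives 58%
compound 3 `COc1ccc(C2=NN(C(=O)C(C)Br)C(c3ccco3)C2)cc1OC` gives 42%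

Compound 3 stands lowest of the three, beyond the scatter below both compound 1 and compound 2, whose two numbers lie within the scatter of each other. Compound 4 `COc1ccc(C2=NN(C(=O)C(C)Br)C(c3c(Cl)cccc3Cl)C2)cc1OC` differs from compound 3 by 2,6-dichlorophenyl in place of furan-2-yl on a saturated ring carbon. Among the compounds with values here, the only measured step, no change at the digits printed from compound 1 to compound 2 (within the scatter), concerns the group on the ring nitrogen and does not bear on this ring exchange. What does bear on it is that compound 1, carrying the 2,6-dichlorophenyl, gives 58%, while compound 3 with the furan-2-yl gives 42%. Compound 4 is therefore expected to rise by a number 12 percentage points higher from compound 3 to compound 4 (beyond the scatter) to an estimated 54%, in a range from 42% to 66%.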

Compound 4, a percentage reported as inhibition, in the whole organism at one dose (the size of the read-out at that dose, not a potency): 60%
For compound 4 the middle estimate is 6 percentage points below the measured one; the measured number falls inside the stated range.
By their numbers in this assay, from the lowest: compound 3; then compounds 1, 2 and 4 (each within the scatter of the next).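

With the (1-bromoethyl)carbonyl group held fixed on the ring nitrogen, the exchange at this saturated ring carbon can be read directly in this assay and gives a number 18 percentage points higher from compound 3 to compound 4 (beyond the scatter). With 2,6-dichlorophenyl in place, the group on the ring nitrogen makes no difference beyond the scatter: 1-bromoethyl for (nitrooxy)methyl gives a number 2 percentage points higher from compound 2 to compound 4 (within the scatter) and (1-bromoethyl)carbonyl for hydrogen gives a number 2 percentage points higher from compound 1 to compound 4 (within the scatter). Nothing available explains these numbers. From the compounds shown here alone, whether furan-2-yl compounds respond in the same way to the group on the ring nitrogen remains open, as does the outcome with an unsubstituted phenyl or a pyridine ring on this ring carbon.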